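Replacing piperazine with 4-methylpiperidine on the sulfonyl sulfur

The source may hold more compounds than are shown below. What is called first, only, known or untested is meant among the compounds shown, and "the series" means these compounds.

Of the compounds shown here, three sharing one core have been measured in an assay on CHO-K1 cells for activation of DNA damage-inducible transcript 3 protein (Homo sapiens), read by a luciferase reporter; a lower number here means that less compound is needed, a higher number that more compound is needed for the effect. Compound 1 `CC1CN(S(=O)(=O)c2ccc(NC(=O)c3ccc([N+](=O)[O-])o3)cc2)CC(C)O1` gives 1400 nM in this assay, compound 2 `O=C(Nc1ccc(S(=O)(=O)N2CCNCC2)cc1)c1ccc([N+](=O)[O-])o1` gives 26400 nM, and compound 3 `O=C(Nc1ccc(S(=O)(=O)N2CCC(F)CC2)cc1)c1ccc([N+](=O)[O-])o1` gives 600 nM. Compound 2 stands highest of the three: the step of a 19-fold higher number from compound 1 to compound 2 (1.28 log units; beyond the scatter) and the step of a 44-fold lower number from compound 2 to compound 3 (1.64 log units; beyond the scatter) are both well beyond the scatter, so compound 2 needs clearly more compound than either neighbour.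

Compound 4 `CC1CCN(S(=O)(=O)c2ccc(NC(=O)c3ccc([N+](=O)[O-])o3)cc2)CC1` is not yet measured. It differs from compound 2 in one place: 4-methylpiperidin-1-yl in place of piperazin-1-yl on a sulfonyl sulfur. The step from compound 2 to compound 3 bears on this directly, since it also removes the piperazin-1-yl from the sulfonyl sulfur in favour of a six-membered ring with a single nitrogen, and it lowered the number by a 44-fold lower number from compound 2 to compound 3 (1.64 log units; beyond the scatter). The step of a 19-fold higher number from compound 1 to compound 2 (1.28 log units; beyond the scatter) points the same way when read backwards. A large fall in this assay is therefore expected for compound 4, about a 38-fold lower number from compound 2 to compound 4 (1.58 log units; beyond the scatter). Compound 4 is estimated at 700 nM, with a likely range from 250 nM to 2500 nM.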

Compound 4, concentration for half-maximal activity: 700 nM
Compound 4: middle estimate and measured number agree at the digits printed; low and high end bracket the measured number.
By their numbers in this assay, from the lowest: compounds 3, 4 and 1 (each within the scatter of the next, the first and the last beyond it); then compound 2.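

In this assay, a 38-fold lower number from compound 2 to compound 4 (1.58 log units; beyond the scatter) shows that the large fall on leaving piperazin-1-yl does not depend on the fluoro group of compound 3, since 4-methylpiperidin-1-yl gives a fall of the same order. Methyl in place of fluoro on a saturated ring carbon, a 1.2-fold higher number from compound 3 to compound 4 (0.07 log units; within the scatter), leaves the number unchanged within the scatter, and 4-methylpiperidin-1-yl in place of 2,6-dimethylmorpholin-4-yl, a 2.0-fold lower number from compound 1 to compound 4 (0.30 log units; within the scatter), also stays within it. Among these four compounds, the ring on the sulfonyl sulfur thus matters chiefly in that piperazin-1-yl stands apart from the other three, although compounds 1 and 3 remain beyond the scatter of each other.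

On these data alone, whether the high number of compound 2 would persist with 4-methylpiperazin-1-yl or 4-acetylpiperazin-1-yl, or whether a carboxylic acid on the piperidine ring would raise the number likewise, stays open. Nothing available here explains the size of these steps.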